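Swapping the chlorofluorophenyl for a methylphenyl group

The source may report more compounds than this note shows. Statements on the series, on what has been measured and on what is new or still open speak of the compounds shown alone.

Compounds measured so far in a functional assay on NCI-H1975 cells (Homo sapiens) for antiproliferative activity, read by MTT assay, with a stated time of 72 h; on this read-out lower numbers stand for stronger inhibition and higher numbers for weaker inhibition:
compound 1 `COc1cc2ncnc(Nc3cccc(Cl)c3)c2cc1OCCCCC(=O)Nc1ccc(S(N)(=O)=O)cc1` gives 33200 nM;
compound 2 `COc1cc2ncnc(Nc3ccc(Cl)cc3)c2cc1OCCCCC(=O)Nc1ccc(S(N)(=O)=O)cc1` gives 31800 nM;
compound 3 `COc1cc2ncnc(Nc3cccc(Cl)c3F)c2cc1OCCCCC(=O)Nc1ccc(S(N)(=O)=O)cc1` gives 6930 nM.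

Compound 3 holds the lowest number of the three, and its distance to both neighbours lies beyond the scatter: a 4.8-fold lower number from compound 1 to compound 3 (0.68 log units; beyond the scatter) and a 4.6-fold lower number from compound 2 to compound 3 (0.66 log units; beyond the scatter). Compound 1 and compound 2, by contrast, sit within the scatter of each other, as a 1.0-fold lower number from compound 1 to compound 2 (0.02 log units; within the scatter) shows.

Compound 4 `COc1cc2ncnc(Nc3cccc(C)c3)c2cc1OCCCCC(=O)Nc1ccc(S(N)(=O)=O)cc1` is the next member of the series. The change from compound 3 is 3-methylphenyl in place of 3-chloro-2-fluorophenyl on a nitrogen on an aromatic ring. Among the measured compounds shown here, two measured steps bear on it. The fluoro that sets compound 3 apart from compound 1 is worth a 4.8-fold lower number from compound 1 to compound 3 (0.68 log units; beyond the scatter), and the full swap from the 4-chlorophenyl of compound 2 to the 3-chloro-2-fluorophenyl of compound 3 is worth a 4.6-fold lower number from compound 2 to compound 3 (0.66 log units; beyond the scatter). Compound 4 keeps neither the fluorine nor the chlorine; it carries only a methyl on the 3-position. The closest measured relative is therefore compound 1 with its 3-chlorophenyl, and a number of that order is expected for compound 4. The estimated step is a 5.1-fold higher number from compound 3 to compound 4 (0.70 log units; beyond the scatter), back towards weaker inhibition. Compound 4 is expected to give about 35000 nM, most likely between 12000 nM and 100000 nM.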

Compound 4, half-maximal inhibitory concentration: 32100 nM
For compound 4 the middle estimate is 1.1-fold (0.04 log units) above the measured one; the range from low to high includes it.
By their numbers in this assay, from the lowest: compound 3; then compounds 2, 4 and 1 (each within the scatter of the next).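

In this assay, the step of methyl in place of chloro on an aromatic carbon stays inside the scatter, at a 1.0-fold lower number from compound 1 to compound 4 (0.01 log units; within the scatter), and the 3-methylphenyl group is just as hard to tell apart from the 4-chlorophenyl group, at a 1.0-fold higher number from compound 2 to compound 4 (0.00 log units; within the scatter). Chlorine is therefore not needed on this ring for a number of this order, and compounds 1, 2 and 4 form one level despite their different groups on the nitrogen. Only the 3-chloro-2-fluorophenyl group of compound 3 stands apart from that level, as a 4.6-fold higher number from compound 3 to compound 4 (0.67 log units; beyond the scatter) shows, and no measurement at hand says why these groups rank as they do.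

Going by these compounds, what remains open is whether a fluoro on the ring of compound 4 would give a step like the one seen with the chloro series, a 4.8-fold lower number from compound 1 to compound 3 (0.68 log units; beyond the scatter), or whether that step depends on chlorine being present too. On these data alone, it is also open how a bromo, a methoxy or an ethynyl group would compare with the methyl of compound 4 on this ring.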